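The compounds below may be only part of what the source reports. "The series", "measured", "known", "first", "only" and "open" are said of these compounds alone.

Compound 1 `O=C(O)Cc1sc(C(c2ccc(F)cc2)c2ccc(F)cc2)nc1-c1ccccc1`: 80%
Compound 2 `COc1cc(-c2nc(C(c3ccc(F)cc3)c3ccc(F)cc3)sc2CC(=O)O)ccn1`: 60%
Compound 3 `NS(=O)(=O)c1ccc(-c2nc(C(c3ccc(F)cc3)c3ccc(F)cc3)sc2CC(=O)O)cc1`: 80%

In an in vitro functional assay on HEK285-7 cells for antagonist activity at prostaglandin D2 receptor 2 (Homo sapiens), read by BRET and beta-arrestin recruitment (on this read-out higher numbers stand for larger maximal responses and lower numbers for smaller maximal responses), compound 3 stands level with compound 1: the step of no change at the digits printed from compound 1 to compound 3 (within the scatter) is within the scatter. Among the compounds with values here, the only step beyond the scatter is a number 20 percentage points higher from compound 2 to compound 3 (beyond the scatter), which mirrors a number 20 percentage points lower from compound 1 to compound 2 (beyond the scatter) when a pyridinyl group entered in place of phenyl. Compound 4 `Cc1cc(-c2nc(C(c3ccc(F)cc3)c3ccc(F)cc3)sc2CC(=O)O)cnc1N` differs from compound 3 in one place: 6-amino-5-methylpyridin-3-yl in place of 4-sulfamoylphenyl on an aromatic carbon. A pyridinyl group again enters at this position, so the relevant step is a number 20 percentage points lower from compound 1 to compound 2 (beyond the scatter), a modest fall, though the amino and methyl groups here are not tested anywhere else. A modest decrease is therefore expected for compound 4, estimated as a number 15 percentage points lower from compound 3 to compound 4 (beyond the scatter), giving an expected maximal response of 65% within the range 50% to 80%.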

Compound 4, largest response reached (reported as efficacy), in percent of the reference or control that the assay uses: 80%
Estimate against measurement, compound 4: 15 percentage points below; low and high end bracket the measured number.
By their numbers in this assay, from the lowest: compound 2; then compounds 1, 3 and 4 (each within the scatter of the next).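

In this assay, a pyridinyl group at this position does not by itself lower the response: the swap to 6-amino-5-methylpyridin-3-yl gives no change at the digits printed from compound 3 to compound 4 (within the scatter) and no change at the digits printed from compound 1 to compound 4 (within the scatter), but a number 20 percentage points higher from compound 2 to compound 4 (beyond the scatter). The fall seen with 2-methoxypyridin-4-yl therefore does not extend to every pyridinyl group. Nothing available explains the difference between these two groups.

The compounds shown leave open whether the amino group, the methyl group or the placing of the ring nitrogen separates them. A plain pyridin-3-yl group or a 6-aminopyridin-3-yl group could tell these apart.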